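This account rests on a few compounds, and the source may have more. Where it says the series, first, only, none or still open, it means among the compounds named here.

Working notes on the series. Compound 1 `CCOC(=O)c1cnc2n(c1=O)C(C)CC/C2=N\Nc1ccccc1`, compound 2 `CC1CC/C(=N\Nc2ccc(F)cc2)c2ncc(C(=O)O)c(=O)n21` and compound 3 `C[C@@H]1CC/C(=N\Nc2ccc(O)cc2)c2ncc(C(=O)O)c(=O)n21` share one core and differ in the group on the amine nitrogen. All three were tested in a functional assay on the whole organism for inhibition, with Rattus norvegicus as the target; a lower number here means that less compound is needed, a higher number that more compound is needed for the effect. In this assay compound 1 gives only a limit, > 1000 umol/kg. In this assay compound 2 also gives only a limit, > 1000 umol/kg. Compound 3 gives a limit as well, > 100 umol/kg in this assay. Compound 2 therefore stands at the limit of > 1000 umol/kg in this assay, at which 2 of the 3 values shown sit, where compound 1 also sits, while compound 3 sits at the limit of > 100 umol/kg in this assay, at which 1 of the 3 values shown sits; with limits only, no order among the three can be read.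

Compound 4 `Cc1cccc(N/N=C2\CCC(C)n3c2ncc(C(=O)O)c3=O)c1` is not yet measured in this assay. The change from compound 2 is 3-methylphenyl in place of 4-fluorophenyl on an amine nitrogen. Going by the values given here, no step between measured compounds exists, so nothing sizes this change. Because compound 2 sits at the limit of > 1000 umol/kg in this assay, at which 2 of the 3 values shown sit, the step from compound 2 to compound 4 is expected to be a number no higher from compound 2 to compound 4 (the limit leaves the size open), nothing beyond the scatter. For compound 4 the expected value in this assay is 1000 umol/kg, estimated between 300 umol/kg and 3000 umol/kg, and most likely reported as a limit again.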

Compound 4, dose for 50% inhibition: 72.5 umol/kg
Compound 4: middle estimate off by 14-fold (1.14 log units), on the high side, and the stated range ends above it.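

In this assay, going by these compounds alone, 3-methylphenyl in place of 4-fluorophenyl on an amine nitrogen gives an at least 13-fold lower number from compound 2 to compound 4 (1.13 log units; beyond the scatter), so the group at this position can shift the dose, which the limits of the earlier compounds could not show. Compound 4 holds the only value in the series that is a number and not a limit, and the size of the step is a lower bound set by the limit of compound 2: the limit of > 1000 umol/kg in this assay, at which 2 of the 4 values shown sit.

The step exchanges the whole aryl group, so it does not separate the loss of the fluorine from the gain of the methyl, or either from the change in ring position. From the compounds shown here alone, how 3-fluorophenyl, 4-methylphenyl or 3-ethylphenyl would read on the same core stays open, and so does whether any of them would give a number and not a limit.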